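The source may report more compounds than this note shows. Statements on the series, on what has been measured and on what is new or still open speak of the compounds shown alone.

Measured so far:
compound 1 `CC(C)CN/C(=N\C#N)NCCCCc1c[nH]cn1`; in an in vitro functional assay on Sf9 cells for antagonist activity at histamine H2 receptor (Homo sapiens) (a higher number here means a more potent compound, by a factor of ten per unit of this negative logarithm, a lower number a less potent compound), compound 1 gives < 5, which is a limit of the assay and not a number.
compound 2 `N#C/N=C(/NCCCCCc1c[nH]cn1)NCCCc1ccccc1`; in this assay compound 2 gives 5.28.
compound 3 `CN/C(=N\C#N)NCCCCCc1c[nH]cn1`; in this assay compound 3 gives 5.66.

Compound 3 holds the higher of the two numbers shown, with compound 2 nearest: the step of a number 0.38 log units higher from compound 2 to compound 3 (beyond the scatter) removes the phenethyl from the amine-bearing carbon and raises the read-out. Compound 1 sits at the limit of < 5 in this assay, at which 1 of the 3 values shown sits.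

Compound 4 `CC(C)CN/C(=N\C#N)NCCCCCc1c[nH]cn1` follows from compound 3 by isopropyl in place of hydrogen on a saturated chain carbon bound to an amine nitrogen. For the measured compounds named here, the one measured step that bears on it runs the other way: stripping a large group from that carbon gained modestly from compound 2 to compound 3, so putting a group back on is expected to cost. Compound 1, carrying the same isobutylamino on a shorter chain, offers only a limit and no number to size the cost. The expected step is a number 0.46 log units lower from compound 3 to compound 4 (beyond the scatter). For compound 4 the estimate in this assay is 5.2, within 4.6 to 5.8.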

Compound 4, negative logarithm of the antagonist equilibrium constant: < 5
Compound 4 was reported as a limit; the forecaster's own chance of this, stated with the estimate: 30%; middle value at least 0.20 log units away from the limit.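

In this assay, isopropyl in place of hydrogen on a saturated chain carbon bound to an amine nitrogen gives a number at least 0.66 log units lower from compound 3 to compound 4 (beyond the scatter), so at this position the loss is not confined to phenethyl, and hydrogen stands above both groups. Isopropyl in place of phenethyl gives a number at least 0.28 log units lower from compound 2 to compound 4 (that floor lies within the scatter), so the two substituted compounds have no order that can be relied on. Compound 4 stands at a limit of the assay and not at a number, and with compound 1 also at a limit, the step between those two cannot be read: the limit of < 5 in this assay, at which 2 of the 4 values shown sit.

As far as these compounds go, how far compound 4 lies past its limit stays open, and with it the true size of both readable steps. Also open, from the compounds shown here alone, is whether ethyl or cyclopropyl at this position would keep a measurable read-out, which would show how much group this carbon can carry.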